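The compounds below may be only part of what the source reports. "The series", "measured", "known", "first", "only" and "open" are said of these compounds alone.

Working notes on the series. In an assay on microsomes from liver for inhibition of 3-hydroxy-3-methylglutaryl-coenzyme A reductase (Rattus norvegicus) (a higher number here means a weaker inhibitor, a lower number a stronger inhibitor), compound 1 `CC(C)c1c(C(=O)N(C)Cc2ccccc2)nn(-c2ccc(F)cc2)c1OC[C@@H](O)C[C@@H](O)CC(=O)O` gives 5.2 nM, the lowest of the three numbers in hand. Compound 2 `Cc1ccccc1CNC(=O)c1nn(-c2ccc(F)cc2)c(OC[C@@H](O)C[C@@H](O)CC(=O)O)c1C(C)C` gives 17 nM and compound 3 `COCc1cccc(CNC(=O)c2nn(-c3ccc(F)cc3)c(OC[C@@H](O)C[C@@H](O)CC(=O)O)c2C(C)C)c1` gives 31 nM; the steps are a 3.3-fold higher number from compound 1 to compound 2 (0.51 log units; beyond the scatter) and a 6.0-fold higher number from compound 1 to compound 3 (0.78 log units; beyond the scatter), both beyond the scatter, while a 1.8-fold higher number from compound 2 to compound 3 (0.26 log units; within the scatter) stays within it. Compound 4 `CC(C)c1c(C(=O)NCc2ccccc2Cl)nn(-c2ccc(F)cc2)c1OC[C@@H](O)C[C@@H](O)CC(=O)O` has not been measured in this assay. It differs from compound 1 in one place: (2-chlorobenzyl)amino in place of benzyl(methyl)amino on a carbonyl carbon. The two measured steps that bear on this change both start from compound 1 and both replace the benzyl(methyl)amino group with a substituted benzylamino group, and both raise the number by a modest amount. The change to compound 4 is of the same kind, with a 2-chlorobenzyl group entering where compound 2 carries a 2-methylbenzyl group. Because of a 3.3-fold higher number from compound 1 to compound 2 (0.51 log units; beyond the scatter) a modest rise is expected here as well, and the step to compound 4 is estimated at a 2.9-fold higher number from compound 1 to compound 4 (0.46 log units; beyond the scatter). Compound 4 is therefore expected to give 15 nM in this assay, within a range of 7 nM to 35 nM.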

Compound 4, half-maximal inhibitory concentration: 9.5 nM
Compound 4: middle estimate off by 1.6-fold (0.20 log units), on the high side; the measured number falls inside the stated range.
By their numbers in this assay, from the lowest: compounds 1, 4, 2 and 3 (each within the scatter of the next, the first and the last beyond it).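

On the carbonyl carbon, (2-chlorobenzyl)amino in place of benzyl(methyl)amino gives a 1.8-fold higher number from compound 1 to compound 4 (0.26 log units; within the scatter) in this assay, so a group carrying the amide hydrogen can stay within the scatter of benzyl(methyl)amino, which the steps to compound 2 and compound 3 did not show. Chloro in place of methyl on an aromatic carbon gives a 1.8-fold lower number from compound 2 to compound 4 (0.25 log units; within the scatter), whereas 2-chlorophenyl in place of 3-(methoxymethyl)phenyl gives a 3.3-fold lower number from compound 3 to compound 4 (0.51 log units; beyond the scatter), the only step among these three benzylamino compounds that lies beyond the scatter. No measurement at hand offers an explanation for these steps.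

The compounds shown leave open how the 2-chlorobenzyl group would read with a methyl in place of the amide hydrogen. Also open, as far as these compounds go, is what bromo or trifluoromethyl in place of chloro would give in this assay.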